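Cytotoxicity notes: aryl ether change on compound 1

The source may hold more compounds than are shown below. What is called first, only, known or untested is meant among the compounds shown, and "the series" means these compounds.

Measured so far:
compound 1 `CC(CCNC(=O)c1c(Cl)cncc1Cl)N1CCC(C(Oc2ccccn2)c2ccc(C(F)(F)F)cc2)CC1` gives 34100 nM in an ADME assay on PBMC cells (Homo sapiens) for cytotoxicity; a lower number here means that less compound is tolerated, a higher number that more compound is tolerated.
compound 2 `CCO/N=C(/c1ccc(Br)cc1)C1CCN(C(CC)CCNC(=O)c2c(C)cc[n+]([O-])c2C)CC1` in this assay gives > 177000 nM, which is a limit of the assay.

Going by the values given here, compound 1 therefore holds the only numerical value; the other result is a limit, (the limit of > 177000 nM in this assay, at which 1 of the 2 values shown sits). Compound 3 `COC(=O)c1cccc(OC(c2ccc(C(F)(F)F)cc2)C2CCN(C(C)CCNC(=O)c3c(Cl)cncc3Cl)CC2)c1` differs from compound 1 as follows: 3-(methoxycarbonyl)phenyl in place of pyridin-2-yl on an oxygen on a saturated carbon. Among the compounds with values here, no step between measured compounds is available, so the step in this assay is expected to stay within the usual scatter, a 1.1-fold lower number from compound 1 to compound 3 (0.03 log units; within the scatter). Compound 3 is estimated at 32000 nM, with a range from 10000 nM to 110000 nM.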

Compound 3, half-maximal cytotoxic concentration: 15200 nM
Compound 3: middle estimate off by 2.1-fold (0.32 log units), on the high side, and the stated range covers the measured number.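

In this assay, 3-(methoxycarbonyl)phenyl in place of pyridin-2-yl on the oxygen gives a 2.2-fold lower number from compound 1 to compound 3 (0.35 log units; beyond the scatter). The group on this oxygen therefore affects the tolerated concentration, though this single step is modest. Nothing shown accounts for the direction of this step.

From the compounds shown here alone, it remains open whether the step follows the methoxycarbonyl group or the change from a ring with a nitrogen to a ring of carbon only. Plain phenyl, or a carboxylic acid in place of the methoxycarbonyl group, would help separate these two changes.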